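Series notes: replacing the aminoacyl arm of compound 3

The source may report more compounds than this note shows. Statements on the series, on what has been measured and on what is new or still open speak of the compounds shown alone.

Measured so far in a functional assay on K562 cells (Homo sapiens) for cytotoxicity, read by trypan blue exclusion, with a stated time of 96 h; on this read-out higher numbers stand for weaker inhibition and lower numbers for stronger inhibition:

compound 1, `COc1ccc(CS(=O)(=O)/C=C/c2c(OC)cccc2OC)c([N+](=O)[O-])c1`, 50000 nM
compound 2, `COc1ccc(CS(=O)(=O)/C=C/c2c(OC)cc(O)cc2OC)cc1[N+](=O)[O-]`, 5000 nM
compound 3, `COC(=O)C(F)(F)Nc1cc(CS(=O)(=O)/C=C/c2c(OC)cc(OC)cc2OC)ccc1OC`, 250 nM

Compound 3 carries the lowest number of the three. Its nearest neighbour on the scale is compound 2, whose value lies beyond the scatter above it, and compound 1 sits further still, also beyond the scatter. Going by the values given here, no two of the measured compounds differ in a single place, so no counted step connects them; the three values only show that compound 3 is the strongest inhibitor of the set in this assay.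

The next compound, compound 4, `COc1cc(OC)c(/C=C/S(=O)(=O)Cc2ccc(OC)c(NC(C(=O)O)c3ccc(Cl)cc3)c2)c(OC)c1`, differs from compound 3 in one place: carboxy(4-chlorophenyl)methyl in place of difluoro(methoxycarbonyl)methyl on a nitrogen on an aromatic ring. The rest of the molecule, including the shared core, is unchanged.

Among the compounds with values here, no measured pair reports what such an exchange on the nitrogen does. The change is nonetheless large, and with nothing to anchor it the expectation is a step from compound 3 to compound 4 of a 2.0-fold higher number from compound 3 to compound 4 (0.30 log units; within the scatter), weakening, and small enough that it might fall inside the scatter. Compound 4 is therefore estimated at 500 nM in this assay, within a range of 100 nM to 3000 nM.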

Compound 4, half-maximal inhibitory concentration: 250 nM
Compound 4: the middle estimate sits 2.0-fold (0.30 log units) above what was measured, within the range that was stated.
By their numbers in this assay, from the lowest: compounds 3 and 4 (each within the scatter of the next); then compound 2; then compound 1.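

Series notes, continued: in this assay, carboxy(4-chlorophenyl)methyl in place of difluoro(methoxycarbonyl)methyl on a nitrogen on an aromatic ring gives no change at the digits printed from compound 3 to compound 4 (within the scatter) and supplies the first counted step of the series. Going by these compounds alone, at this position, therefore, the arm can go from 7 heavy atoms with 2 fluorine atoms and no ring to 11 heavy atoms with one six-membered aromatic ring of carbon only, 1 chlorine and 1 hydrogen-bond donor, with compound 4 still reading alike with compound 3, and the earlier compounds gave no view of such an exchange. No supporting measurement is at hand to explain why the two arms read alike.

As far as these compounds go, the 4-chlorophenyl part and the carboxy part enter together in this single step, so the contribution of each on its own remains open. Also open, from the compounds shown here alone, is how this assay would read with a plain amino group at this nitrogen, with the methyl ester of compound 4, or with an unsubstituted phenyl in place of 4-chlorophenyl on the same arm.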